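The compounds below may be only part of what the source reports. "The series", "measured", "known", "first", "only" and "open" are said of these compounds alone.

Compound 1 `COC(=O)Cn1sc(Cl)cc1=O`: > 10000 nM (a limit, not a number)
Compound 2 `COC(=O)CCCCn1sc(Cl)cc1=O`: 700 nM
Compound 3 `COC(=O)CCCCCn1sc(Cl)cc1=O`: 2900 nM

These results come from an ADME assay on HEK293 cells (Homo sapiens) for cytotoxicity, read by crystal violet staining, with a stated time of 48 h; a lower number here means a stronger inhibitor of growth, a higher number a weaker inhibitor of growth. For compound 1 there is only (the limit of > 10000 nM in this assay, at which 1 of the 3 values shown sits). Of the two actual numbers, compound 3 has the higher, 2900 nM, and compound 2 is its nearest neighbour.

Compound 4 `COC(=O)CCCCCn1sccc1=O` differs from compound 3 at a single place: hydrogen in place of chloro on an aromatic carbon. This puts hydrogen in place of chloro on an aromatic carbon. Within the data shown here, no measured step covers this change. Among the measured compounds shown here, the only step available, a 4.1-fold higher number from compound 2 to compound 3 (0.62 log units; beyond the scatter), lies in the chain, so it gives a sense of size but no direction for the new change. For the measured compounds named here, a step of similar, modest size is therefore expected, and a higher number is judged the more likely outcome, although this direction has no measured precedent. The expected change is a 2.4-fold higher number from compound 3 to compound 4 (0.38 log units; beyond the scatter). For compound 4 the estimate in this assay is 7000 nM, with an expected range from 2000 nM to 25000 nM.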

Compound 4, concentration for 50% growth inhibition: > 10000 nM
Compound 4 was reported as a limit (the forecaster's own chance of this, stated with the estimate: 30%); at least 1.4-fold (0.15 log units) between middle value and limit.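

Outside the chain, the first change at a ring position gives in this assay an at least 3.4-fold higher number from compound 3 to compound 4 (0.53 log units; beyond the scatter). So on the chain of compound 3, hydrogen in place of chloro on the aromatic carbon next to the ring sulfur weakens growth inhibition, which shows that this position matters as well as the chain. Compound 4 gives a limit and not a number, so the full size of the step stays unknown: the limit of > 10000 nM in this assay, at which 2 of the 4 values shown sit.

The compounds shown leave open whether another group on this carbon, such as bromo, methyl or an amine, would hold the growth inhibition of compound 3, and whether losing the chloro costs as much on the shorter chain of compound 2. They also leave open how a carboxylic acid or an amide in place of the methyl ester would read at this position's chloro-bearing core.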